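A few compounds are considered here, and "the series" means these few. Any claim that something is new, unique, unknown or untested is made for them only; others in the source may bear on it.

Measured compounds:
- compound 1, `O=C(/C=C/c1ccncc1)c1cccc(C(F)(F)F)c1`: 41000 nM
- compound 2, `N#Cc1ccc(C(=O)/C=C/c2ccncc2)cc1`: 123000 nM
- compound 3, `O=C(c1ccccc1)c1ccccc1-c1cccnc1`: > 100000 nM

All three were tested in a functional assay with Rattus norvegicus as the target; a higher number here means a weaker inhibitor, a lower number a stronger inhibitor. For compound 3 the result is a limit of the assay rather than a number, (the limit of > 100000 nM in this assay, at which 1 of the 3 values shown sits). Among the two compounds that did give a number, compound 2 stands highest, that is, it is the weaker inhibitor of the pair. Its nearest neighbour is compound 1, whose number is lower, and the gap between them lies beyond the scatter of repeated measurements.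

Compound 4, `CSc1ccc(C(=O)/C=C/c2ccncc2)cc1`, has not yet been tested. It differs from compound 2 in one place: methylsulfanyl in place of cyano on an aromatic carbon. Among the compounds with values here, no pair of measured compounds differing only in this way has been tested, so there is no measured step to lean on. Both groups sit on the same aromatic carbon, and the two compounds that gave numbers are both weak, so the expectation is for a modest move, with compound 4 estimated to come out somewhat lower than compound 2, a step of a 2.1-fold lower number from compound 2 to compound 4 (0.31 log units; beyond the scatter). The estimate for compound 4 in this assay is 60000 nM, expected to fall between 15000 nM and 200000 nM.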

Compound 4, half-maximal inhibitory concentration: 33000 nM
For compound 4 the middle estimate is 1.8-fold (0.26 log units) above the measured one; low and high end bracket the measured number.
By their numbers in this assay, from the lowest: compounds 4 and 1 (each within the scatter of the next); then compound 2.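

In this assay, putting methylsulfanyl in place of cyano on this aromatic carbon, para to a large group, gives a 3.7-fold lower number from compound 2 to compound 4 (0.57 log units; beyond the scatter). Within the data shown here, this is the first direct evidence that the group at this position can shift the result, since the earlier compounds offered no pair differing in one place only. The two groups have the same counts of heavy atoms and hydrogen-bond acceptors and neither carries a net charge, so those counts do not separate them, and nothing measured here says why the number moved.

A single step gives one pair and one direction, so it cannot show a trend across groups at this position. From the compounds shown here alone, whether an amine, a carboxylic acid or a longer chain such as ethylsulfanyl on the same carbon would lower the number further or raise it stays open, as does whether methylsulfanyl would give a similar step with the rest of the molecule changed.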